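A few compounds are considered here, and "the series" means these few. Any claim that something is new, unique, unknown or untested is made for them only; others in the source may bear on it.

For the measured compounds named here, compound 1 `O=C(O)c1cc(-c2cccc(COc3ccc4c(c3)CN(C3CCCC3)C4=O)c2)ccc1O` gives the lowest of the two numbers measured so far in an assay on HEK293 cells for positive allosteric modulation of metabotropic glutamate receptor 2 (Rattus norvegicus), read by thallium flux (a lower number here means that less compound is needed, a higher number that more compound is needed for the effect), at 20 nM. Compound 2 `O=C(O)c1cc(-c2cccc(COc3ccc4c(=O)n(C5CCC5)sc4c3)c2)ccc1Cl`, built on a different core, gives 580 nM in this assay. Compound 3 `O=C(O)c1ccc(-c2cccc(COc3ccc4c(c3)CN(C3CCCC3)C4=O)c2)c(Cl)c1` is compound 1 with one replacement: 4-carboxy-2-chlorophenyl in place of 3-carboxy-4-hydroxyphenyl on an aromatic carbon. Going by the values given here, no measured pair shows this change on its own, so its size is uncertain; the expectation is a moderate loss of potency, meaning a higher number, as the step of a 5.0-fold higher number from compound 1 to compound 3 (0.70 log units; beyond the scatter). Compound 3 is estimated at 100 nM in this assay, within a likely range from 25 nM to 400 nM.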

Compound 3, half-maximal effective concentration: 110 nM
Compound 3: the middle estimate sits 1.1-fold (0.04 log units) below what was measured; the range from low to high includes it.
By their numbers in this assay, from the lowest: compound 1; then compound 3; then compound 2.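

On the shared core, replacing 3-carboxy-4-hydroxyphenyl with 4-carboxy-2-chlorophenyl gives a 5.5-fold higher number from compound 1 to compound 3 (0.74 log units; beyond the scatter) in this assay. This shows that the group at this position affects the result, yet the replacement still leaves a measurable effect. No available measurement explains the size of this step.

As far as these compounds go, the carboxy group changes place and the hydroxy group gives way to chlorine in one step, so the share of each change stays open. From the compounds shown here alone, whether an amine could stand in place of the carboxylic acid is also open.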